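From 4-methylphenyl to 4-ethylphenyl

The source may report more compounds than this note shows. Statements on the series, on what has been measured and on what is new or still open speak of the compounds shown alone.

Compound 1 `O=C(Nc1ccccc1)C1CCN(C/C=C/c2ccccc2)CC1` gives 69700 nM
Compound 2 `Cc1ccc(NC(=O)C2CCN(C/C=C/c3ccccc3)CC2)cc1` gives 29600 nM

In a functional assay on A549 cells (Homo sapiens) for inhibition, read by MTT assay, with a stated time of 72 h (on this read-out higher numbers stand for weaker inhibition and lower numbers for stronger inhibition), compound 2 gives 29600 nM and so holds the lower of the two numbers. Compound 3 `CCc1ccc(NC(=O)C2CCN(C/C=C/c3ccccc3)CC2)cc1` differs from compound 2 through methyl in place of hydrogen on a saturated chain carbon bound to an aromatic carbon. Within the data shown here, the one measured step bearing on this is a 2.4-fold lower number from compound 1 to compound 2 (0.37 log units; beyond the scatter) and it also put methyl in place of hydrogen, though on an aromatic carbon. A similar or smaller step toward a lower number is therefore expected. The estimated change is a 1.5-fold lower number from compound 2 to compound 3 (0.17 log units; within the scatter) at the middle of the range. Compound 3 is expected near 20000 nM with a range from 8000 nM to 50000 nM as the estimate.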

Compound 3, half-maximal inhibitory concentration: 19600 nM
The estimate for compound 3 lay 1.0-fold (0.01 log units) above the measured number; the range from low to high includes it.
By their numbers in this assay, from the lowest: compounds 3 and 2 (each within the scatter of the next); then compound 1.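

In this assay, methyl to ethyl gives a 1.5-fold lower number from compound 2 to compound 3 (0.18 log units; within the scatter), so on the saturated chain carbon bound to an aromatic carbon the added methyl does not separate compound 3 from compound 2. The ethyl group taken as a whole still gives a 3.6-fold lower number from compound 1 to compound 3 (0.55 log units; beyond the scatter), a step beyond the scatter. No measurement shown here accounts for these numbers. The compounds shown leave open whether a longer chain such as propyl, or an amine or a carboxylic acid in place of the ethyl, would stand beyond the scatter from compound 3.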